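A hydroxy group joins the 4-methylphenyl compound

A few compounds are considered here, and "the series" means these few. Any claim that something is new, unique, unknown or untested is made for them only; others in the source may bear on it.

Compound 1 `CCN1C(=O)N(c2cccc(OC)c2)C(=O)N(c2ccccc2)c2cc(C(F)(F)F)ccc21`, compound 2 `CCN1C(=O)N(c2ccc(O)cc2)C(=O)N(c2ccccc2)c2cc(C(F)(F)F)ccc21` and compound 3 `CCN1C(=O)N(c2ccc(C)cc2)C(=O)N(c2ccccc2)c2cc(C(F)(F)F)ccc21` share one core and differ only in the aromatic group on an amide-type nitrogen in a ring. In an ADME assay on C8166 cells (Homo sapiens) for cytotoxicity (on this read-out lower numbers stand for higher toxicity in this test and higher numbers for lower toxicity in this test), compound 3 gives > 6500 nM, which is a limit and not a number. Compound 1 gives > 20000 nM, which is also a limit. Within the data shown here, compound 2 gives 35000 nM, the only true number of the three.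

Compound 4 `CCN1C(=O)N(c2ccc(O)c(C)c2)C(=O)N(c2ccccc2)c2cc(C(F)(F)F)ccc21` arises from compound 3 by one change: 4-hydroxy-3-methylphenyl in place of 4-methylphenyl on an amide-type nitrogen in a ring. The measured steps that bear on it are a step that the limit leaves unreadable from compound 2 to compound 3, a step that the limit leaves unreadable from compound 1 to compound 2 and a step that the two limits leave unreadable from compound 1 to compound 3, so none of them offers a size to carry over. Among the measured compounds shown here, the best guide is the one readable value: compound 4 keeps a hydroxy group in the 4-hydroxy position of its phenyl group, as does compound 2 at 35000 nM. A value near that one is therefore expected in this assay. For compound 4 the estimated value is 30000 nM. The estimated range for compound 4 runs from 10000 nM to 80000 nM. The expected step, a step that the limit leaves unreadable from compound 3 to compound 4, leans towards a higher number, but only loosely.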

Compound 4, half-maximal cytotoxic concentration: 17000 nM
Compound 4: the middle estimate sits 1.8-fold (0.25 log units) above what was measured; the range from low to high includes it.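

In this assay, the methyl group added to the 4-hydroxyphenyl group gives the first readable size for a change at this position, with a 2.1-fold lower number from compound 2 to compound 4 (0.31 log units; beyond the scatter), so this small addition moves the read-out modestly towards higher toxicity in this test. The comparison with the 3-methoxyphenyl group gives only a floor, with an at least 1.1-fold lower number from compound 1 to compound 4 (0.07 log units; that floor lies within the scatter), and so it sets no clear order between the two groups. The step from the 4-methylphenyl group cannot be read because compound 3 carries only a limit: the limit of > 6500 nM in this assay, at which 1 of the 4 values shown sits.

On these data alone, it remains open whether an ethyl group or a chlorine atom in place of the added methyl would move the read-out by a similar amount. As far as these compounds go, it is also open how an amine or a carboxylic acid in place of the hydroxy group would read.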